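This account rests on a few compounds, and the source may have more. Where it says the series, first, only, none or still open, it means among the compounds named here.

Measured compounds in a functional assay on SW480 cells (Homo sapiens) for cytotoxicity, read by MTT assay, with a stated time of 48 h; a higher number here means a weaker inhibitor, a lower number a stronger inhibitor:
- compound 1 `CCOC(=O)[C@]1(C(=O)Nc2ccccc2Cl)C[C@@H]1c1cc(OC)c(OC)c(OC)c1` gives > 100000 nM, which is a limit of the assay rather than a number.
- compound 2 `CCOC(=O)[C@@]1(C(=O)Nc2ccccc2Cl)C[C@H]1c1cc(OC)c(OC)c(OC)c1` gives 30100 nM.

For the measured compounds named here, compound 2 thus holds the only actual number obtained in this assay; the other result is a limit. The step of an at least 3.3-fold lower number from compound 1 to compound 2 (0.52 log units; beyond the scatter) rests on (the fact that compounds 1 and 2 differ only in the configuration as drawn), and how far it can be sized is fixed by the limit of > 100000 nM in this assay, at which 1 of the 2 values shown sits.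

Compound 3 `CCOC(=O)[C@@]1(C(=O)NCc2ccc(C)cc2)C[C@H]1c1cc(OC)c(OC)c(OC)c1` is not yet measured. It differs from compound 2 in one place: 4-methylbenzyl in place of 2-chlorophenyl on an amide-type nitrogen. Going by the values given here, no measured step touches the group on the amide-type nitrogen; the only step in hand, from compound 1 to compound 2, concerns configuration alone and carries no information about this exchange. The change from compound 2 to compound 3 therefore has no precedent among these compounds, and the expectation leans on the value of compound 2 in this assay, 30100 nM, with a wide margin for the unknown. The step of a 1.0-fold lower number from compound 2 to compound 3 (0.00 log units; within the scatter) is what this expectation implies, a step not beyond the scatter. Compound 3 is accordingly estimated at 30000 nM, between 7000 nM and 130000 nM.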

Compound 3, half-maximal inhibitory concentration: > 100000 nM
Compound 3 gave a limit, no number; the forecaster's own chance of this, stated with the estimate: 30%; middle value at least 3.3-fold (0.52 log units) away from the limit.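

In this assay compound 3 gives > 100000 nM, which is a limit of the assay and not a number. For the compounds shown here, this is the first change that goes beyond configuration, and replacing 2-chlorophenyl with 4-methylbenzyl on the amide-type nitrogen gives an at least 3.3-fold higher number from compound 2 to compound 3 (0.52 log units; beyond the scatter), so the group at this place clearly influences the read-out even though the shared core and its drawn configuration stay the same. The true size of this loss of cytotoxic effect cannot be stated, and the step only gives its smallest possible size: the limit of > 100000 nM in this assay, at which 2 of the 3 values shown sit.

The exchange alters two features at once, with benzyl replacing phenyl and methyl replacing chlorine, and the compounds shown cannot say which of these matters or whether both do. A 2-chlorobenzyl or 4-methylphenyl group on the same nitrogen would separate the two features, while a plain phenyl group would show whether the chlorine on the ring is needed at all.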